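Replacing the thiophene of compound 3 with 4-ethoxyphenyl

A few compounds are considered here, and "the series" means these few. Any claim that something is new, unique, unknown or untested is made for them only; others in the source may bear on it.

Compound 1 `COc1cc(C(=O)c2sc(-c3ccc(Cl)cc3)cc2N)cc(OC)c1OC` gives 90 nM
Compound 2 `COc1cc(C(=O)c2sc(-c3ccc(I)cc3)cc2N)cc(OC)c1OC` gives 420 nM
Compound 3 `COc1cc(C(=O)c2sc(-c3cccs3)cc2N)cc(OC)c1OC` gives 1.7 nM
Compound 4 `CCOc1ccc(-c2cc(N)c(C(=O)c3cc(OC)c(OC)c(OC)c3)s2)cc1` has not yet been measured

In a functional assay on FM3A cells (Mus musculus) for antiproliferative activity (a lower number here means a stronger inhibitor, a higher number a weaker inhibitor), compound 3 gives 1.7 nM and holds the lowest of the three numbers, with compound 1 nearest and compound 2 furthest. The step followed here leads to compound 4, with 4-ethoxyphenyl in place of thiophen-2-yl on an aromatic carbon next to the ring sulfur 4-ethoxyphenyl in place of thiophen-2-yl on an aromatic carbon and the rest of the structure unchanged.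

Within the data shown here, two measured steps bear on this change, as both join a 4-substituted phenyl to the thiophen-2-yl of compound 3. The first is large, a 53-fold lower number from compound 1 to compound 3 (1.72 log units; beyond the scatter), and the second is larger still, a 250-fold lower number from compound 2 to compound 3 (2.39 log units; beyond the scatter). Compound 4 reverses that kind of change, so a higher number is expected. The substituent on the phenyl also counts, since a 4.7-fold higher number from compound 1 to compound 2 (0.67 log units; beyond the scatter) is a modest step beyond the scatter. Among the measured compounds shown here, no ethoxy compound has been measured, so the size remains uncertain, and a large step is expected, probably somewhat smaller than those two. The estimated step is an 18-fold higher number from compound 3 to compound 4 (1.25 log units; beyond the scatter) in this reading. For compound 4 the estimated value is 30 nM, with an expected range from 4 nM to 200 nM in this assay.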

Compound 4, half-maximal inhibitory concentration: 510 nM
Compound 4: middle estimate off by 17-fold (1.23 log units), on the low side; measured number outside the range, above it.
By their numbers in this assay, from the lowest: compound 3; then compound 1; then compounds 2 and 4 (each within the scatter of the next).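

In this assay, the step away from thiophen-2-yl on this aromatic carbon next to the ring sulfur is also large when the incoming group is 4-ethoxyphenyl, a 300-fold higher number from compound 3 to compound 4 (2.48 log units; beyond the scatter), so all three 4-substituted phenyl compounds shown have higher numbers than compound 3, and none goes against this. The identity of the phenyl substituent gives a mixed picture: ethoxy in place of iodo gives a 1.2-fold higher number from compound 2 to compound 4 (0.08 log units; within the scatter), so those two compounds cannot be told apart, whereas ethoxy in place of chloro gives a 5.7-fold higher number from compound 1 to compound 4 (0.75 log units; beyond the scatter), a modest step. Of the three phenyl compounds, compound 1 therefore holds the lowest number, and an oxygen-linked ethyl chain on the phenyl does not bring the activity back towards that of compound 3.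

The compounds shown leave open whether a methoxy or dimethylamino group on the phenyl, or a furan-2-yl ring in place of the thiophen-2-yl, would keep a number close to that of compound 3. Nothing presented here accounts for the size of these steps.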